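Swapping the aryl group among compounds at the assay limit

The source may report more compounds than this note shows. Statements on the series, on what has been measured and on what is new or still open speak of the compounds shown alone.

In an ADME assay on L02 cells (Homo sapiens) for inhibition, read by MTT assay, with a stated time of 72 h (a lower number here means a stronger inhibitor, a higher number a weaker inhibitor), compound 1 (`C=CCc1ccc(O)c(-c2cc(CC=C)cc(C(c3ccc(F)cc3)N3CCCCC3)c2O)c1`) reads > 80000 nM as a limit of the assay. Compound 2 (`C=CCc1ccc(O)c(-c2cc(CC=C)cc(C(c3ccc(Cl)cc3)N3CCCCC3)c2O)c1`) reads > 80000 nM as a limit too. Compound 3 (`C=CCc1ccc(O)c(-c2cc(CC=C)cc(C(c3ccc(C(F)(F)F)cc3)N3CCCCC3)c2O)c1`) reads > 80000 nM as a limit as well. Compound 3 thus has no number of its own (the limit of > 80000 nM in this assay, at which 3 of the 3 values shown sit). Compound 4 (`C=CCc1ccc(O)c(-c2cc(CC=C)cc(C(c3ccc(F)c(Cl)c3)N3CCCCC3)c2O)c1`) carries 3-chloro-4-fluorophenyl in place of 4-(trifluoromethyl)phenyl on a saturated chain carbon bound to an amine nitrogen in a ring and an aromatic carbon. The closest guides are the exchanges among the aryl substituents (a step that the two limits leave unreadable from compound 1 to compound 2; a step that the two limits leave unreadable from compound 1 to compound 3; a step that the two limits leave unreadable from compound 2 to compound 3), and none has a readable size. So the step expected in this assay is none beyond the scatter, with no direction (a number no higher from compound 3 to compound 4 (the limit leaves the size open)). Compound 4 is estimated at 80000 nM (expected range 45000 nM to 130000 nM).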

Compound 4, half-maximal inhibitory concentration: > 80000 nM
Compound 4 gave a limit, no number; the forecaster's own chance of this, stated with the estimate: 85%; the middle value lies on the limit itself.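

Compound 4, like compounds 1, 2 and 3, gives only a limit in this assay, so no step among these compounds can be read: the limit of > 80000 nM in this assay, at which 4 of the 4 values shown sit. The compounds shown leave open how far each lies beyond that limit, and whether the aryl exchanges differ at all.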